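From trifluoromethyl to fluoro in the cinnamyl amide series

The source may report more compounds than this note shows. Statements on the series, on what has been measured and on what is new or still open speak of the compounds shown alone.

Compound 1 `O=C(Nc1ccccc1)C1CCN(C/C=C/c2ccccc2)CC1`: 69700 nM
Compound 2 `COc1ccccc1NC(=O)C1CCN(C/C=C/c2ccccc2)CC1`: > 100000 nM (a limit, not a number)
Compound 3 `O=C(Nc1cccc(C(F)(F)F)c1)C1CCN(C/C=C/c2ccccc2)CC1`: 15600 nM

In a functional assay on A549 cells (Homo sapiens) for inhibition, read by MTT assay, with a stated time of 72 h (on this read-out higher numbers stand for weaker inhibition and lower numbers for stronger inhibition), compound 3 holds the lower of the two true numbers, with compound 1 the nearest. Compound 4 `O=C(Nc1cccc(F)c1)C1CCN(C/C=C/c2ccccc2)CC1` replaces the group as follows: fluoro in place of trifluoromethyl on an aromatic carbon. The step bearing most directly is trifluoromethyl in place of hydrogen, with a 4.5-fold lower number from compound 1 to compound 3 (0.65 log units; beyond the scatter). The methoxy step, with an at least 1.4-fold higher number from compound 1 to compound 2 (0.15 log units; that floor lies within the scatter), rests on a limit and offers little guidance. Compound 4 lacks the trifluoromethyl, so part of that first step is expected to be given back, with the number rising. The expected change is a 2.2-fold higher number from compound 3 to compound 4 (0.35 log units; beyond the scatter). The estimate for compound 4 is 35000 nM (range 14000 nM to 85000 nM).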

Compound 4, half-maximal inhibitory concentration: 43300 nM
The estimate for compound 4 lay 1.2-fold (0.09 log units) below the measured number, within the range that was stated.
By their numbers in this assay, from the lowest: compound 3; then compounds 4 and 1 (each within the scatter of the next). At a limit, above all of these: compound 2.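

In this assay, fluoro in place of trifluoromethyl gives a 2.8-fold higher number from compound 3 to compound 4 (0.44 log units; beyond the scatter). Fluoro in place of hydrogen gives a 1.6-fold lower number from compound 1 to compound 4 (0.21 log units; within the scatter), so at this aromatic carbon, of the two groups shown, only trifluoromethyl gives a step from compound 1 that lies beyond the scatter. Compound 2 is held at a limit, not a number, so an at least 2.3-fold lower number from compound 2 to compound 4 (0.36 log units; beyond the scatter) is only a floor: the limit of > 100000 nM in this assay, at which 1 of the 4 values shown sits.

Open, on these data alone, is whether a nitrile or a carboxylic acid at this aromatic carbon would match trifluoromethyl. Also open, as far as these compounds go, is how trifluoromethyl behaves on the other carbons of this ring.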